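The source may report more compounds than this note shows. Statements on the series, on what has been measured and on what is new or still open speak of the compounds shown alone.

Compound 1 `CC(=O)c1cc(C)c(OCCCCC#N)cc1O`: 35%
Compound 2 `CCCCCCc1cc(C(C)=O)c(O)cc1OCCCCC#N`: 13%
Compound 3 `CC(=O)c1cc(C(C)=O)c(OCCCCC#N)cc1O`: not yet measured

In an assay on isolated protein for binding affinity to leukotriene B4 receptor 1 (Homo sapiens), tested at 1 uM (on this read-out lower numbers stand for less inhibition and higher numbers for more inhibition at the one concentration tested (going by the name of the read-out)), compound 1 gives 35%, while compound 2 gives 13%. Among the compounds with values here, compound 2 thus stands lowest of the two measured numbers, with compound 1 as its only neighbour. Within the data shown here, the single measured step, a number 22 percentage points lower from compound 1 to compound 2 (beyond the scatter), is pentyl in place of hydrogen on a saturated chain carbon bound to an aromatic carbon; adding the chain to the core of compound 1 lowered inhibition by a modest margin.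

Compound 3 differs from compound 2 by acetyl in place of hexyl on an aromatic carbon. The measured step bears on this only in part: it shows what the chain cost, a number 22 percentage points lower from compound 1 to compound 2 (beyond the scatter), so taking hexyl away may give back roughly that much and bring compound 3 toward compound 1. Among the measured compounds shown here, what acetyl adds on the same aromatic carbon has no measured counterpart. A modest rise is therefore expected, a number 17 percentage points higher from compound 2 to compound 3 (beyond the scatter), with wide uncertainty. Compound 3 is estimated at 30% in this assay, between 10% and 50%.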

Compound 3, a percentage reported as inhibition, at one concentration (the size of the read-out at that concentration, not a potency): 0%
The estimate for compound 3 lay 30 percentage points above the measured number; the measured number lies below the stated range.
By their numbers in this assay, from the lowest: compound 3; then compound 2; then compound 1.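

In this assay, three groups can now be compared at the aromatic carbon ortho to a 4-cyanobutoxy group and para to a hydroxy group: the change to acetyl gives a number 35 percentage points lower from compound 1 to compound 3 (beyond the scatter) with methyl leaving, and a number 13 percentage points lower from compound 2 to compound 3 (beyond the scatter) with hexyl leaving. The drop seen on going to hexyl therefore does not mean that a smaller group reads higher here: acetyl, with 3 heavy atoms against 6 for hexyl, stands lowest of the three, so heavy-atom count alone does not order this position, and compound 3 goes against any such trend. Nothing available explains why acetyl reads lowest at this carbon.

Still open, on these data alone, is whether an ethyl group, which keeps the two carbons of acetyl without its carbonyl, would read closer to compound 1 or to compound 3, and how an amine or a carboxylic acid would read on the same carbon. The 4-cyanobutoxy group and the hydroxy group stay the same across all three compounds, so their contribution is unresolved, and numbers at a single concentration leave potency open.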